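The compounds below may be only part of what the source reports. "The series", "measured", "known", "first", "only" and "open" are said of these compounds alone.

Measured compounds and their values:
- compound 1, `C=CC1=C(C(=O)Nc2ccccc2OC)C(c2ccc(F)cc2)OC1`: > 100000 nM
- compound 2, `C=CC1=C(C(=O)NCc2ccccc2F)C(c2ccc(F)cc2)OC1`: > 100000 nM
- compound 3, `C=CC1=C(C(=O)Nc2ccccc2)C(c2ccc(F)cc2)OC1`: > 100000 nM

Each of these three values is a limit of a functional assay on A549 cells (Homo sapiens) for cytotoxicity, read by MTT assay, with a stated time of 24 h (a higher number here means a weaker inhibitor, a lower number a stronger inhibitor), not a measured number. Compound 1 therefore has no exact position on the numbers shown; it simply sits at the limit of > 100000 nM in this assay, at which 3 of the 3 values shown sit. The same holds for compound 2 and for compound 3, so the three steps among them, a step that the two limits leave unreadable from compound 1 to compound 2, a step that the two limits leave unreadable from compound 1 to compound 3 and a step that the two limits leave unreadable from compound 2 to compound 3, cannot be read in size or direction.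

Compound 4, `C=CC1=C(C(=O)Nc2ccccc2OC)C(c2ccc(Cl)c(Cl)c2)OC1`, differs from compound 1 in one place: 3,4-dichlorophenyl in place of 4-fluorophenyl on a saturated ring carbon. Within the data shown here, none of the measured steps touches this part of the shared core; they all alter the group on the amide-type nitrogen, and none of them yields a readable size. Among the measured compounds shown here, there is thus no measured step that bears on the change from compound 1 to compound 4, and no direction can be inferred from the data.

With all three measured compounds at the limit, compound 4 is expected to be weak in this assay as well, most likely reported again only as a limit. The estimate for compound 4 is 120000 nM, with a range from 30000 nM to 400000 nM. This expected step, a step that the limit leaves unreadable from compound 1 to compound 4, is not one that the data can support beyond the scatter.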

Compound 4, half-maximal inhibitory concentration: > 100000 nM
Compound 4: only a limit was reported; the forecaster's own chance of this, stated with the estimate: 75%; the middle value lies beyond the limit too.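

In this assay compound 4 gives > 100000 nM, which is a limit and not a number, so the step between compound 1 and compound 4 cannot be read in size or direction. All the compounds shown stand at the same point: the limit of > 100000 nM in this assay, at which 4 of the 4 values shown sit.

Still open, going by these compounds, is how far 3,4-dichlorophenyl in place of 4-fluorophenyl changes cytotoxic strength, and whether any of these four compounds has a measurable value.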